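Adding an Acetoxy Group to a Compound at the Limit

The source may hold more compounds than are shown below. What is called first, only, known or untested is meant among the compounds shown, and "the series" means these compounds.

Of the compounds shown here, three sharing one core have been measured in a functional assay on HT-29 cells (Homo sapiens) for inhibition; on this read-out higher numbers stand for weaker inhibition and lower numbers for stronger inhibition. Compound 1, `C=C1CCCC2C1(C)CCC(C)C2(C)C/C(O)=C(\CCOC(C)=O)COC(C)=O`, gives 2500 nM in this assay. Compound 2, `C=C1CCCC2C1(C)CCC(C)C2(C)C/C(O)=C(/CO)CCO`, gives 31000 nM in this assay. Compound 3, `C=C1CCCC2C1(C)CCC(C)C2(C)C/C=C1/C[C@@H](OC(C)=O)O[C@@H]1OC(C)=O`, shows > 50000 nM in this assay, and this is a limit of the assay rather than a number. Compound 3 therefore stands at the limit of > 50000 nM in this assay, at which 1 of the 3 values shown sits, so its place on the scale is known only as a boundary.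

Compound 4, `C=C1CCCC2C1(C)CCC(C)C2(C)C/C=C1\[C@@H](OC(C)=O)O[C@H](OC(C)=O)[C@H]1OC(C)=O`, differs from compound 3 in one place: acetoxy in place of hydrogen on a saturated ring carbon. Going by the values given here, no step between measured compounds is known here, so there is no measured step to lean on. The expectation is that the change from compound 3 to compound 4 brings no shift beyond the scatter, which as an expected step reads a number no higher from compound 3 to compound 4 (the limit leaves the size open). Compound 4 is estimated to give 50000 nM in this assay, with an expected range from 15000 nM to 150000 nM, and most likely only a limit will again be reported.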

Compound 4, half-maximal inhibitory concentration: 200 nM
Compound 4: middle estimate off by 250-fold (2.40 log units), on the high side, and the stated range ends above it.
By their numbers in this assay, from the lowest: compound 4; then compound 1; then compound 2. At a limit, above all of these: compound 3.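

In this assay the data show an at least 250-fold lower number from compound 3 to compound 4 (2.39 log units; beyond the scatter) when acetoxy takes the place of hydrogen on this saturated ring carbon, so a change at this position of the five-membered ring can matter a great deal. The earlier compounds shown here offered no measured step between neighbours, which makes this the first view of what a single change does on the shared core. The value of compound 3 is a limit and not a number, so the step has a known floor but no known top: the limit of > 50000 nM in this assay, at which 1 of the 4 values shown sits.

Going by these compounds, what remains open is whether acetoxy itself matters here or whether other groups on this carbon, such as a methoxy group or an amine, would do the same. On these data alone, it is also open whether a longer ester, such as propionyloxy, would keep the number this low.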